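Amide nitrogen substitution and oral inhibition in the mouse

The compounds below may be only part of what the source reports. "The series", "measured", "known", "first", "only" and "open" are said of these compounds alone.

Measured so far:
compound 1 `CSc1ccc2c(c1)c(O)c(C(=O)Nc1ccccc1)c(=O)n2C` — 24%
compound 2 `CCN(C(=O)c1c(O)c2cc(SC)ccc2n(C)c1=O)c1ccccc1` — 89%

In a functional assay on the whole organism for inhibition, with Mus musculus as the target, at a dose of 32 mg/kg by the oral route (a lower number here means less inhibition, a higher number more inhibition at the dose given (going by the name of the read-out)), compound 1 gives 24%, the lowest of the two numbers, and compound 2 gives 89%. Within the data shown here, the only step with a measured outcome is a number 65 percentage points higher from compound 1 to compound 2 (beyond the scatter), a large gain. Compound 3 `CSc1ccc2c(c1)c(O)c(C(=O)N(C)c1ccccn1)c(=O)n2C` carries methyl(pyridin-2-yl)amino in place of anilino on a carbonyl carbon. A methyl on the amide-type nitrogen matches the kind of change seen in the step from compound 1 to compound 2, but nothing measured bears on the pyridin-2-yl in place of phenyl. The expected step is estimated as a number 41 percentage points higher from compound 1 to compound 3 (beyond the scatter), with wide uncertainty. Compound 3 is estimated at 65%, within 30% to 95%.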

Compound 3, a percentage reported as inhibition, in the whole organism at one dose (the size of the read-out at that dose, not a potency): 65%
The estimate for compound 3 equals the measured number at the digits printed, and the stated range covers the measured number.
By their numbers in this assay, from the lowest: compound 1; then compound 3; then compound 2.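

In this assay, methyl(pyridin-2-yl)amino in place of anilino on a carbonyl carbon gives a number 41 percentage points higher from compound 1 to compound 3 (beyond the scatter) and shows that a large gain also occurs with a change other than the ethyl of compound 2. Both changes remove the amide hydrogen, but this step also exchanges the phenyl for pyridin-2-yl, so the contribution of each part cannot be separated. Nothing at hand explains the gain.

Still open, going by these compounds, is how the methyl alone, with phenyl retained, or pyridin-2-yl alone, with the amide hydrogen retained, would read. A propyl on the amide-type nitrogen also lies outside the compounds shown.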